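Chain Length Around a Shared Lactone Core

The source may report more compounds than this note shows. Statements on the series, on what has been measured and on what is new or still open speak of the compounds shown alone.

Compound 1 `CC(C)(C)C(=O)OCC1(CO)C/C(=C\CCCCCCCCCCCO)C(=O)O1`: 0.65 ug/mL
Compound 2 `CC(C)(C)C(=O)OCC1(CO)C/C(=C/CCCCCCCCCCCCCCC=O)C(=O)O1`: > 10 ug/mL

Going by the values given here, in a functional assay on CCRF-CEM cells (Homo sapiens) for antiproliferative activity (a higher number here means a weaker inhibitor of growth, a lower number a stronger inhibitor of growth), compound 1 gives the only numerical value, 0.65 ug/mL. For compound 2 the result is a limit, (the limit of > 10 ug/mL in this assay, at which 1 of the 2 values shown sits), and not a number. Compound 3 `CCCCCCCCC(O)CCCCCC/C=C1\CC(CO)(COC(=O)C(C)(C)C)OC1=O` differs from compound 1 by 1-hydroxynonyl in place of 5-hydroxypentyl on a saturated chain carbon, six bonds along the chain from a double-bonded chain carbon. Among the compounds with values here, no step between two measured compounds is available, so any expectation rests on compound 1 alone. A modest weakening beyond the scatter is expected, a 2.3-fold higher number from compound 1 to compound 3 (0.36 log units; beyond the scatter). Compound 3 is therefore estimated at 1.5 ug/mL, within 0.5 ug/mL to 5 ug/mL.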

Compound 3, concentration for 50% growth inhibition: 5.72 ug/mL
Beside the measured number, compound 3's estimate is 3.8-fold (0.58 log units) below it; the whole stated range lies below it.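

In this assay, putting 1-hydroxynonyl in place of 5-hydroxypentyl on a saturated chain carbon, six bonds along the chain from a double-bonded chain carbon, gives an 8.8-fold higher number from compound 1 to compound 3 (0.94 log units; beyond the scatter), so growth inhibition at this position responds to this change. Both groups count 1 hydrogen-bond donor and 1 hydrogen-bond acceptor, so the step comes with those counts unchanged. Nothing measured here gives a reason for the step.

This single step cannot separate the larger group from the changed hydroxyl placement. Going by these compounds, whether a shorter chain, or an amine or carboxylic acid in place of the hydroxyl, would restore growth inhibition stays open.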